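Series notes: acyl chain branching from compound 3 to compound 4

The source may report more compounds than this note shows. Statements on the series, on what has been measured and on what is new or still open speak of the compounds shown alone.

Three phenols of this series have been measured in an assay on HEK293 cells for positive allosteric modulation of metabotropic glutamate receptor 3 (Rattus norvegicus), read by thallium flux, with a stated time of 2.5 min; on this read-out higher numbers stand for larger maximal responses and lower numbers for smaller maximal responses. Compound 1 `Cc1c(OCCCCOc2ccc(C(=O)O)cc2)ccc(C(=O)CC2CCCC2)c1O` gives 26.7%, and compound 2 `Cc1c(OCCCCOc2ccc(C(=O)C(C)C)c(O)c2C)cccc1C(=O)O` gives 27.1%. Compound 3 `CCC(=O)c1ccc(OCCCCOc2cc(C(=O)O)ccc2OC)c(C)c1O` gives 62.5%, the highest of the three numbers; its gaps to compound 2 and to compound 1 both lie beyond the scatter. No pair among these three differs in one place only, so no single step can be isolated.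

Compound 4 `COc1ccc(C(=O)O)cc1OCCCCOc1ccc(C(=O)C(C)C)c(O)c1C` remains to be measured in this assay. Its difference from compound 3 is methyl in place of hydrogen on a saturated chain carbon bound to a carbonyl carbon and a saturated chain carbon. Compound 2, which also carries the isopropylcarbonyl group but a differently substituted second ring, sits far lower than compound 3, yet that pair differs in more than one place and says nothing direct about the branching alone. The step from compound 3 to compound 4 is expected to be small, within the scatter, or slightly downward: a number 7.5 percentage points lower from compound 3 to compound 4 (within the scatter). For compound 4 the estimate is 55%, between 30% and 75%.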

Compound 4, largest response reached (reported as percent of maximum), in percent of the reference or control that the assay uses: 59.9%
Beside the measured number, compound 4's estimate is 4.9 percentage points below it, and the stated range covers the measured number.
By their numbers in this assay, from the lowest: compounds 1 and 2 (each within the scatter of the next); then compounds 4 and 3 (each within the scatter of the next).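

Among these compounds, the step from propanoyl to isopropylcarbonyl is the first that can be read on its own: in this assay it is a number 2.6 percentage points lower from compound 3 to compound 4 (within the scatter). With everything else in the structure held constant, the added methyl on this saturated chain carbon does not separate the two compounds on this read-out, so the branch is tolerated here, at least with the rest of compound 3 in place. Nothing at hand bears on why the response holds across this change.

As far as these compounds go, this is a single pair, so it remains open whether the same tolerance holds when the rest of the core differs. Also open, from the compounds shown here alone, is how far the position can be extended, for example to tert-butylcarbonyl or to a longer straight chain such as butanoyl.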